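One double bond, drawn the other way

The source may hold more compounds than are shown below. What is called first, only, known or untested is meant among the compounds shown, and "the series" means these compounds.

In a physicochemical assay for lipophilicity (on this read-out higher numbers stand for higher lipophilicity and lower numbers for lower lipophilicity), compound 1 `C/C(=C/C(=O)O)C(=O)c1ccccc1` gives 1.69 while compound 2 `C/C(=C\C(=O)O)C(=O)c1ccc(C)cc1` gives 2.94 and so stands the higher of the two, a gap beyond the usual scatter. Compound 3 `C/C(=C/C(=O)O)C(=O)c1ccc(C)cc1` has yet to be measured. It has the same atoms and bonds as compound 2 and differs only in configuration as drawn, (the two compounds have the same atoms and bonds and differ only in configuration as drawn: 1 of 1 stereo elements differ; a double bond is drawn E in compound 2 and Z in compound 3), a double bond being drawn E in compound 2 and Z in compound 3. Among the compounds with values here, no measured pair shows such a change in this assay, so a moderate fall beyond the scatter is only expected, with an estimated a number 0.64 log units lower from compound 2 to compound 3 (beyond the scatter) as its size. For compound 3 the estimated value is 2.3 with an expected range from 1.7 to 2.9 in this measurement.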

Compound 3, partition coefficient: 2.19
Compound 3: the middle estimate sits 0.11 log units above what was measured; the measured number falls inside the stated range.
By their numbers in this assay, from the lowest: compound 1; then compound 3; then compound 2.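

In this assay the configuration of the double bond matters on its own, bringing a number 0.75 log units lower from compound 2 to compound 3 (beyond the scatter). With that configuration drawn alike in both compounds, methyl in place of hydrogen on an aromatic carbon gives a number 0.50 log units higher from compound 1 to compound 3 (beyond the scatter), so the methyl step can now be read separately. The first step can be assigned to the double bond alone because of one fact: the fact that compounds 2 and 3 differ only in the configuration as drawn.

The compounds shown leave open whether a longer chain or a methoxy group in place of that methyl would move the number the same way. They also leave open whether an amide in place of the carboxylic acid would keep the gap between the two configurations.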